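Hydrogen in Place of Methyl: An Expectation for Compound 4

The compounds below may be only part of what the source reports. "The series", "measured", "known", "first", "only" and "open" are said of these compounds alone.

Compound 1 `Cc1cc(C)c2c(O)cc(-c3ccc(Cl)cc3)nc2n1` and compound 3 `Cc1ccnc2nc(-c3ccc(Cl)cc3)cc(O)c12` share a core and differ in one place, the change being (hydrogen in place of methyl on an aromatic carbon). In a functional assay on MDA-N cells (Homo sapiens) (on this read-out higher numbers stand for weaker inhibition of growth and lower numbers for stronger inhibition of growth), compound 1 gives 3630 nM, and in this assay compound 3 gives 1320 nM, so the step is a 2.8-fold lower number from compound 1 to compound 3 (0.44 log units; beyond the scatter).

Compound 2 `COc1cccc(-c2cc(O)c3c(C)cc(C)nc3n2)c1` carries a different aryl group; how its core differs from that of compound 1 is not broken down here. In this assay compound 2 gives < 10 nM, which is a limit of the assay rather than a number. This is the limit of < 10 nM in this assay, at which 1 of the 3 values shown sits.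

Compound 4 `COc1cccc(-c2cc(O)c3c(C)ccnc3n2)c1` has not yet been measured. It differs from compound 2 by hydrogen in place of methyl on an aromatic carbon. The surroundings of the changed position read the same, word for word, as those of the change from compound 1 to compound 3, so it is the same change applied to a second core.

Because the measured step is a 2.8-fold lower number from compound 1 to compound 3 (0.44 log units; beyond the scatter), the step from compound 2 to compound 4 in this assay is expected to be of a similar modest size, estimated as a step that the limit leaves unreadable from compound 2 to compound 4. Since compound 2 already sits at a limit, compound 4 is estimated to give about 5 nM, with a likely range from 1.5 nM to 20 nM, and the assay may well report only a limit again.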

Compound 4, concentration for 50% growth inhibition: < 10 nM
Compound 4 ended at the assay's limit; the forecaster's own chance of this, stated with the estimate: 60%; the middle value does not contradict the limit.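

In this assay compound 4, like compound 2, stands at a limit of the assay and not at a number, so no step between the two can be read: the limit of < 10 nM in this assay, at which 2 of the 4 values shown sit.

The compounds shown leave open whether hydrogen in place of methyl on an aromatic carbon, which gave a 2.8-fold lower number from compound 1 to compound 3 (0.44 log units; beyond the scatter) on the core of compound 1, moves the number to a similar extent on the core of compound 2.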